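Replacing methoxy with fluoro at a solubility limit

The compounds below may be only part of what the source reports. "The series", "measured", "known", "first", "only" and "open" are said of these compounds alone.

For the measured compounds named here, in a physicochemical assay for solubility, read by nephelometry, measured as kinetic solubility, at pH 2, tested at 10 mg/mL (a higher number here means a more soluble compound, a lower number a less soluble compound), no compound measured so far has given an exact number. Compound 1 `Cc1cc(Br)ccc1C(=O)Nc1ccccn1` gives > 100 ug/mL, which is a limit of the assay and not a number. Compound 2 `Cc1ccccc1C(=O)Nc1cccc(F)n1`, which carries a fluoro group, gives > 100 ug/mL, again a limit. Compound 3 `COc1ccc(NC(=O)c2ccccc2C)nc1` gives > 100 ug/mL, also a limit. Compound 3 therefore has no exact position, and the shared result is the limit of > 100 ug/mL in this assay, at which 3 of the 3 values shown sit.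

Compound 4 `Cc1ccccc1C(=O)Nc1ccc(F)cn1` has not yet been measured. It has fluoro in place of methoxy on an aromatic carbon, two atoms from the ring nitrogen and para to a large group: fluoro in place of methoxy on an aromatic carbon. Going by the values given here, no measured pair shows this change on its own. The expectation leans on compound 2, whose fluoro group comes with > 100 ug/mL, a limit. The expected change in this assay is none beyond the scatter: a step that the limit leaves unreadable from compound 3 to compound 4. For compound 4 the estimated solubility is 130 ug/mL, with an expected range from 70 ug/mL to 250 ug/mL.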

Compound 4, solubility: 25 ug/mL
Compound 4: the middle estimate sits 5.2-fold (0.72 log units) above what was measured, and the stated range ends above it.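

In this assay, the change from methoxy to fluoro on an aromatic carbon, two atoms from the ring nitrogen and para to a large group, gives an at least 4.0-fold lower number from compound 3 to compound 4 (0.60 log units; beyond the scatter) and so shows that this place on the ring does not tolerate every swap equally. For the compounds shown here, compound 4 is the first compound here to give an exact number, which the earlier compounds could not do: the limit of > 100 ug/mL in this assay, at which 3 of the 4 values shown sit. Compound 3 is itself at a limit, so the step gives only the smallest size the fall can have.

The compounds shown leave open whether the lower number follows the loss of methoxy or the arrival of fluoro. A chlorine, an amine or a hydroxyl at this same position could help to separate those two readings.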